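A few compounds are considered here, and "the series" means these few. Any claim that something is new, unique, unknown or untested is made for them only; others in the source may bear on it.

Measured compounds:
compound 1, `O=C(O)c1cccc([C@H]2C[C@@H]2c2ccc(OCc3c(-c4c(Cl)cccc4Cl)noc3C3CC3)cc2Cl)c1`, 88%;
compound 2, `CC(C)n1nc(C(=O)O)cc1[C@@H]1C[C@H]1c1ccc(OCc2c(-c3c(Cl)cccc3Cl)noc2C2CC2)cc1Cl`, 79%.

In an assay on HEK293 cells for agonist activity at Bile acid receptor (Homo sapiens) (a higher number here means a larger maximal response, a lower number a smaller maximal response), compound 2 stands lowest of the two numbers, with compound 1 nearest at a value within the scatter, so the two cannot be ordered. Compound 3, `O=C(O)c1cccc([C@@H]2C[C@H]2c2ccc(OCc3c(-c4c(Cl)cccc4Cl)noc3C3CC3)cc2Cl)c1`, differs from compound 2 by 3-carboxyphenyl in place of 3-carboxy-1-isopropyl-1H-pyrazol-5-yl on a saturated ring carbon. Going by the values given here, no single-change step between measured compounds is available, so the expected step is read from the values alone. Because compound 1 gives 88%, compound 3 is expected to show a number 1 percentage points higher from compound 2 to compound 3 (within the scatter), that is, no change beyond the scatter. Compound 3 is estimated at 80%, within 55% to 100%.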

Compound 3, largest response reached (reported as efficacy), in percent of the reference or control that the assay uses: 98%
Compound 3: middle estimate off by 18 percentage points, on the low side, and the stated range covers the measured number.
By their numbers in this assay, from the lowest: compounds 2, 1 and 3 (each within the scatter of the next, the first and the last beyond it).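

In this assay, 3-carboxyphenyl in place of 3-carboxy-1-isopropyl-1H-pyrazol-5-yl on the saturated ring carbon gives a number 19 percentage points higher from compound 2 to compound 3 (beyond the scatter) at this position. Inverting both stereocentres gives a number 10 percentage points higher from compound 1 to compound 3 (within the scatter) and so does not separate the two mirror images in this read-out, a comparison that isolates stereochemistry through one fact: the fact that compounds 1 and 3 differ only in the configuration as drawn. The compounds shown leave open whether the step from compound 2 to compound 3 follows from the change of ring or from the loss of the isopropyl group. They also leave open how a primary amide or a tetrazole would fare in place of the carboxylic acid.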